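A few compounds are considered here, and "the series" means these few. Any claim that something is new, unique, unknown or untested is made for them only; others in the source may bear on it.

Measured so far in an assay on Sf9 cells for inhibition of Leucine-rich repeat serine/threonine-protein kinase 2 (Homo sapiens), read by TR-FRET, with stated times of 30 min and 2 h; on this read-out lower numbers stand for stronger inhibition and higher numbers for weaker inhibition:
compound 1 `O=C(Nc1ccnnc1)c1cc(N2CCNCC2)ccc1OCc1ccccc1` gives 15.9 nM
compound 2 `O=C(Nc1ccnnc1)c1cc(N2CCCC2)ccc1OCc1ccccc1` gives 20 nM
compound 3 `CN1CCN(c2ccc(OCc3ccccc3)c(C(=O)Nc3ccnnc3)c2)CC1` gives 12.6 nM

Compound 3 stands at the lowest of the three numbers, yet both of its steps lie within the scatter: a 1.3-fold lower number from compound 1 to compound 3 (0.10 log units; within the scatter) and a 1.6-fold lower number from compound 2 to compound 3 (0.20 log units; within the scatter). The remaining step, a 1.3-fold higher number from compound 1 to compound 2 (0.10 log units; within the scatter), is within the scatter as well, so the three ring substituents at this position have so far been indistinguishable in this assay.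

Compound 4 `C[C@@H]1CN(c2ccc(OCc3ccccc3)c(C(=O)Nc3ccnnc3)c2)C[C@H](C)O1` differs from compound 3 in one place: 2,6-dimethylmorpholin-4-yl in place of 4-methylpiperazin-1-yl on an aromatic carbon. Within the data shown here, no measured step introduces the 2,6-dimethylmorpholin-4-yl group, so the three steps above are the only guide, and each is within the scatter. The expected step in this assay is therefore none beyond the scatter, a 1.4-fold higher number from compound 3 to compound 4 (0.15 log units; within the scatter). Compound 4 is estimated at 18 nM, with a range from 7 nM to 50 nM.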

Compound 4, half-maximal inhibitory concentration: 20 nM
Compound 4: middle estimate off by 1.1-fold (0.05 log units), on the low side; low and high end bracket the measured number.
By their numbers in this assay, from the lowest: compounds 3, 1, 2 and 4 (each within the scatter of the next).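

With the 2,6-dimethylmorpholin-4-yl group, a ring oxygen and two defined stereocentres enter at this position, yet the number in this assay stays within the scatter of all three earlier compounds (a 1.6-fold higher number from compound 3 to compound 4 (0.20 log units; within the scatter); no change at the digits printed from compound 2 to compound 4 (within the scatter); a 1.3-fold higher number from compound 1 to compound 4 (0.10 log units; within the scatter)). The position therefore tolerates this change as well, and all four ring substituents remain indistinguishable. No further data bear on this result.

Open, going by these compounds, is whether an acyclic group at this position, such as a carboxylic acid or a longer alkyl chain, would give a step beyond the scatter. Also open, on these data alone, is how the other stereoisomers of the 2,6-dimethylmorpholin-4-yl group would read.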